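The compounds below may be only part of what the source reports. "The series", "measured", "known", "first", "only" and "open" are said of these compounds alone.

Compound 1 `O=c1c(O)c(-c2ccccc2)oc2cc(OCc3ccccc3Br)cc(O)c12` carries a 2-bromobenzyl group on the shared core. In an ADME assay on Huh-5-2 cells (Homo sapiens) for cytotoxicity, read by WST assay, with a stated time of 3 days (on this read-out higher numbers stand for lower toxicity in this test and lower numbers for higher toxicity in this test), compound 1 reads > 100000 nM, which is a limit of the test rather than a number. Compound 2 `N#Cc1ccccc1COc1cc(O)c2c(=O)c(O)c(-c3ccccc3)oc2c1` differs from compound 1 by cyano in place of bromo on an aromatic carbon. In this assay compound 2 gives 22000 nM. That change produced an at least 4.5-fold lower number from compound 1 to compound 2 (0.65 log units; beyond the scatter). Compound 3 `O=c1c(O)c(-c2ccccc2)oc2cc(OCc3ccc(Br)cc3)cc(O)c12` differs from compound 1 by 4-bromophenyl in place of 2-bromophenyl on a saturated chain carbon bound to an oxygen on an aromatic ring. In this assay compound 3 reads > 100000 nM, again a limit of the test and not a number. Compound 4 `N#Cc1ccc(COc2cc(O)c3c(=O)c(O)c(-c4ccccc4)oc3c2)cc1`, not yet measured, differs from compound 3 by cyano in place of bromo on an aromatic carbon. For the measured compounds named here, this is the same kind of change as the one from compound 1 to compound 2, though the place is not identical: there the cyano sits ortho to a large group, here para to a large group. Because compound 1 and compound 3 both sit at the limit of > 100000 nM in this assay, at which 2 of the 3 values shown sit, the starting point of the new step is itself only a limit. For compound 4 the expected step is an at least 2.5-fold lower number from compound 3 to compound 4 (0.39 log units; beyond the scatter). That expectation rests on the measured step of an at least 4.5-fold lower number from compound 1 to compound 2 (0.65 log units; beyond the scatter), a change of the same kind. Compound 4 is estimated at 40000 nM in this assay, with a likely range from 12000 nM to 150000 nM.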

Compound 4, half-maximal cytotoxic concentration: 94000 nM
The estimate for compound 4 lay 2.4-fold (0.37 log units) below the measured number; the measured number falls inside the stated range.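

Compound 3 reads > 100000 nM, which is a limit of the test and not a number. The one firm new result in this assay concerns where the cyano sits: 4-cyanophenyl in place of 2-cyanophenyl gives a 4.3-fold higher number from compound 2 to compound 4 (0.63 log units; beyond the scatter), and a higher number here stands for lower toxicity in this test. Cyano in place of bromo gives only a floor on the second core, an at least 1.0-fold lower number from compound 3 to compound 4 (0.02 log units; that floor lies within the scatter), and the comparison with the first bromo compound is no firmer, an at least 1.0-fold lower number from compound 1 to compound 4 (0.02 log units; that floor lies within the scatter), so the change is shown neither to carry over between the cores nor to fail to: the same change on two cores in this assay, an at least 4.5-fold lower number (0.65 log units; beyond the scatter) from compound 1 to compound 2 and an at least 1.0-fold lower number (0.02 log units; that floor lies within the scatter) from compound 3 to compound 4; the limit leaves it open whether they differ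

On these data alone, how large the step from bromo to cyano really is on the 4-bromobenzyl compound stays open: the limit of > 100000 nM in this assay, at which 2 of the 4 values shown sit. Also open is how an amine or a carboxylic acid on the same benzyl ring, or a longer chain in place of the single carbon bound to the oxygen, would read in this assay.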